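Pyridazine in place of pyridine on the amide nitrogen

The compounds below may be only part of what the source reports. "The series", "measured", "known", "first", "only" and "open" are said of these compounds alone.

Compound 1 `N#Cc1cccc(NC(=O)c2cc(C(F)(F)F)ccc2OCc2ccc(F)cc2)c1`: 7.5
Compound 2 `O=C(Nc1cccnc1)c1cc(C(F)(F)F)ccc1OCc1ccccc1`: 6.3

In a physicochemical assay for lipophilicity, at pH 7.4 (a lower number here means a more polar compound, a higher number a more lipophilic compound), compound 2 has the lower of the two measured numbers; compound 1 lies higher, by a gap beyond the usual scatter. Compound 3 `O=C(Nc1ccnnc1)c1cc(C(F)(F)F)ccc1OCc1ccccc1` has not been measured. It differs from compound 2 in one place: pyridazin-4-yl in place of pyridin-3-yl on an amide-type nitrogen. Within the data shown here, no measured pair here shows this change, so the expectation rests on the change itself. A modest downward step in this assay is expected, somewhat larger than the scatter. The estimated step of a number 0.70 log units lower from compound 2 to compound 3 (beyond the scatter) is expected to place compound 3 at 5.6, within a range from 5 to 6.2.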

Compound 3, distribution coefficient: 5.4
Compound 3: middle estimate off by 0.20 log units, on the high side; measured number inside the range.
By their numbers in this assay, from the lowest: compound 3; then compound 2; then compound 1.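

In this assay, pyridazin-4-yl in place of pyridin-3-yl on the amide-type nitrogen gives a number 0.90 log units lower from compound 2 to compound 3 (beyond the scatter) and extends the range downward. Among these compounds, this is the first pair here that differs in one place, so the size of this change can be read directly, while compound 1 differs from both in more than one place. Nothing available here explains the step.

Going by these compounds, it remains open how a pyrimidin-5-yl ring, or a pyridine carrying an amine, would read on this amide-type nitrogen. One pair also cannot show whether this step would repeat on another core.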